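Mirror image of a potent TRPV1 antagonist

The source may report more compounds than this note shows. Statements on the series, on what has been measured and on what is new or still open speak of the compounds shown alone.

Compound 1 `C[C@H](C(=O)NC[C@H](COC(=O)C(C)(C)C)Cc1ccccc1)c1ccc(NS(C)(=O)=O)c(F)c1`: 8.56 nM
Compound 2 `Cc1ccc(CC(CNC(=O)C2(c3ccc(NS(C)(=O)=O)cc3)CC2)COC(=O)C(C)(C)C)cc1C`: 197 nM

In a functional assay on CHO cells for antagonist activity at transient receptor potential cation channel subfamily V member 1 (Rattus norvegicus) (on this read-out higher numbers stand for weaker inhibition and lower numbers for stronger inhibition), compound 1 gives the lowest number of the two, with compound 2 at 197 nM standing well beyond the scatter. Compound 3 `C[C@@H](C(=O)NC[C@@H](COC(=O)C(C)(C)C)Cc1ccccc1)c1ccc(NS(C)(=O)=O)c(F)c1` is the full mirror image of compound 1: the two compounds have the same atoms and bonds and differ only in configuration as drawn: 2 of 2 stereo elements differ (all stereocentres are inverted: mirror images); a stereocentre at a saturated chain carbon is drawn S in compound 1 and R in compound 3; a stereocentre at a saturated chain carbon is drawn R in compound 1 and S in compound 3. Among the measured compounds shown here, with no measured pair of this kind to lean on, inverting both stereocentres is expected to cost clear potency, so the step of an 18-fold higher number from compound 1 to compound 3 (1.24 log units; beyond the scatter) is estimated as a sizeable rise in the number. Compound 3 is therefore expected to give about 150 nM, within roughly 30 nM to 800 nM.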

Compound 3, inhibition constant: 205 nM
Compound 3: middle estimate off by 1.4-fold (0.14 log units), on the low side; the range from low to high includes it.
By their numbers in this assay, from the lowest: compound 1; then compounds 2 and 3 (each within the scatter of the next).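

In this assay, inverting both stereocentres, with no other change, gives a 24-fold higher number from compound 1 to compound 3 (1.38 log units; beyond the scatter). The loss can be traced to configuration alone, because nothing else separates the pair: the fact that compounds 1 and 3 differ only in the configuration as drawn. Compound 1 and compound 2 differ in more than one place, so they could not isolate this effect. The compounds shown leave open how the step divides between the two stereocentres, since they appear inverted only together. They also leave open whether a step of this size would persist with a carboxylic acid in place of the ester.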